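Compound 3 to compound 4: trifluoromethyl on the phenyl

The source may report more compounds than this note shows. Statements on the series, on what has been measured and on what is new or still open speak of the compounds shown alone.

Measured in an ADME assay on HEK293 cells (Homo sapiens) for cytotoxicity, read by CellTiter-Glo, with a stated time of 72 h (a higher number here means that more compound is needed for the effect, a lower number that less compound is needed), so far:
- compound 1 `C=C1/C=C/C(C)(C)CC2=C(C)C(=O)[C@]3(C[C@@H](C)C=C3/C=C\1C)O2` gives 26000 nM
- compound 2 `COc1ccc(/C2=C\C(=O)/C(C)=C\C3=C[C@H](C)C[C@@]34OC(=C(C)C4=O)CC2(C)C)cc1` gives 26000 nM
- compound 3 `CC1=C2CC(C)(C)/C(c3ccccc3)=C/C(=O)/C(C)=C\C3=C[C@H](C)C[C@]3(O2)C1=O` gives 26000 nM

Compound 3 stands level with compound 1 and compound 2 at the digits shown, so the series offers no spread to work from. Next is compound 4 `CC1=C2CC(C)(C)/C(c3ccc(C(F)(F)F)cc3)=C/C(=O)/C(C)=C\C3=C[C@H](C)C[C@]3(O2)C1=O`, with trifluoromethyl in place of hydrogen on an aromatic carbon, para to a large group (trifluoromethyl in place of hydrogen on an aromatic carbon). Among the compounds with values here, one measured step bears on this aromatic carbon: no change at the digits printed from compound 2 to compound 3 (within the scatter), with hydrogen in place of methoxy. It is a single step with a different group, so it is only a loose guide. The step of no change at the digits printed from compound 3 to compound 4 (within the scatter) is expected to stay within the scatter in this assay with no direction favoured. Compound 4 is estimated at 26000 nM within a range of 13000 nM to 45000 nM on repeat measurement.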

Compound 4, half-maximal effective concentration: 26000 nM
The estimate for compound 4 equals the measured number at the digits printed; the measured number falls inside the stated range.
By their numbers in this assay, from the lowest: compounds 1, 2, 3 and 4 (each within the scatter of the next).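

In this assay trifluoromethyl on the phenyl gives no change at the digits printed from compound 3 to compound 4 (within the scatter) and, set against methoxy on that aromatic carbon, no change at the digits printed from compound 2 to compound 4 (within the scatter) as well. Hydrogen, methoxy and trifluoromethyl at this position now stand level at the digits printed, so three different groups here have yet to separate any compound in this series. No measured evidence bears on this result.

Still open, as far as these compounds go, is whether an amine or a carboxylic acid on this aromatic carbon would stay level with these compounds. From the compounds shown here alone, a change on the shared core away from the phenyl also remains open.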